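Azetidine amide series: carbamate to urea at the azetidine nitrogen

The source may report more compounds than this note shows. Statements on the series, on what has been measured and on what is new or still open speak of the compounds shown alone.

Measured so far in a functional assay on BXPC-3 cells (Homo sapiens) for inhibition, read by MTT assay, with a stated time of 7 days; a higher number here means a weaker inhibitor, a lower number a stronger inhibitor:
compound 1 `CCN(CC)S(=O)(=O)c1ccc(S(=O)(=O)N2CCC[C@@H](C(=O)N(C)C(C)C)C2)cc1` gives 7700 nM;
compound 2 `CCN(CC)S(=O)(=O)c1ccc(S(=O)(=O)N2CCC[C@@H](C(=O)NC)C2)cc1` gives 13800 nM;
compound 3 `CCN(CC)S(=O)(=O)c1ccc(S(=O)(=O)N2CCC[C@@H](C(=O)NC3CN(C(=O)OC(C)(C)C)C3)C2)cc1` gives 1800 nM.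

Compound 3 stands lowest of the three: the steps of a 4.3-fold lower number from compound 1 to compound 3 (0.63 log units; beyond the scatter) and a 7.7-fold lower number from compound 2 to compound 3 (0.88 log units; beyond the scatter) both lie beyond the scatter, whereas a 1.8-fold higher number from compound 1 to compound 2 (0.25 log units; within the scatter) does not. Compound 4 `CCN(CC)S(=O)(=O)c1ccc(S(=O)(=O)N2CCC[C@@H](C(=O)NC3CN(C(=O)NC(C)(C)C)C3)C2)cc1` changes ((tert-butyl)amino in place of tert-butoxy on a carbonyl carbon). Among the compounds with values here, none of the measured steps touches this carbonyl; all concern the substituent on the amide-type nitrogen, and the tert-butoxycarbonyl group stayed the same throughout. Within the data shown here, with no comparable step available, a change beyond the scatter in this assay is not expected in either direction, so the step of no change at the digits printed from compound 3 to compound 4 (within the scatter) is the estimate. Compound 4 is therefore expected at about 1800 nM, between 700 nM and 4500 nM.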

Compound 4, half-maximal inhibitory concentration: 10100 nM
Estimate against measurement, compound 4: 5.6-fold (0.75 log units) below; measured number outside the range, above it.
By their numbers in this assay, from the lowest: compound 3; then compounds 1, 4 and 2 (each within the scatter of the next).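

In this assay, the carbonyl carbon on the ring nitrogen proves to be a sensitive place, untouched by earlier steps: exchanging tert-butoxy for (tert-butyl)amino gives a 5.6-fold higher number from compound 3 to compound 4 (0.75 log units; beyond the scatter). The advantage of compound 3 is not shared by the urea, with a 1.4-fold lower number from compound 2 to compound 4 (0.14 log units; within the scatter) and a 1.3-fold higher number from compound 1 to compound 4 (0.12 log units; within the scatter). No measurement at hand accounts for this step.

Open, on these data alone, is how the number responds to other groups on this carbonyl carbon. Isopropoxy, methoxy or dimethylamino there would test whether the result extends beyond this one pair.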